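Diethylamino Replaces Dimethylamino on the Thiocarbonyl Carbon

The compounds below may be only part of what the source reports. "The series", "measured", "known", "first", "only" and "open" are said of these compounds alone.

Going by the values given here, compound 2 `CN(C)C(=S)SCc1nc2ccccc2[nH]1` gives 2120 nM in a functional assay on the whole organism for inhibition, with Cicer arietinum as the target, with a stated time of 7 days (on this read-out higher numbers stand for weaker inhibition and lower numbers for stronger inhibition), the higher of the two numbers measured so far, by a gap that is within the scatter. Compound 1 `S=C(SCc1nc2ccccc2[nH]1)N1CCCC1` gives 1800 nM in this assay. Among the compounds with values here, the only step recorded, a 1.2-fold higher number from compound 1 to compound 2 (0.07 log units; within the scatter), swapped one amine on the thiocarbonyl carbon for another. Compound 3 `CCN(CC)C(=S)SCc1nc2ccccc2[nH]1` carries a change of the same kind: diethylamino in place of dimethylamino on a thiocarbonyl carbon. Because that earlier step a 1.2-fold higher number from compound 1 to compound 2 (0.07 log units; within the scatter) stayed within the scatter, no shift beyond the scatter is expected in this assay. The expected step is a 1.0-fold higher number from compound 2 to compound 3 (0.02 log units; within the scatter). Compound 3 is therefore estimated at 2200 nM, with a range from 1100 nM to 4400 nM.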

Compound 3, half-maximal inhibitory concentration: 1860 nM
Compound 3: middle estimate off by 1.2-fold (0.07 log units), on the high side; the range from low to high includes it.
By their numbers in this assay, from the lowest: compounds 1, 3 and 2 (each within the scatter of the next).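

On the thiocarbonyl carbon, diethylamino in place of dimethylamino gives a 1.1-fold lower number from compound 2 to compound 3 (0.06 log units; within the scatter) in this assay and so cannot be told apart from it, even with 5 heavy atoms entering for 3. Diethylamino in place of pyrrolidin-1-yl gives a 1.0-fold higher number from compound 1 to compound 3 (0.01 log units; within the scatter) and so shows the same for an open chain against a ring, leaving all three amines within the scatter of one another. Nothing here explains this tolerance.

On these data alone, whether morpholin-4-yl, a longer chain such as dibutylamino, or a chain ending in a carboxylic acid would shift the number beyond the scatter remains open.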